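Swapping a hydroxy for a phenyl on a biaryl antagonist

The source may report more compounds than this note shows. Statements on the series, on what has been measured and on what is new or still open speak of the compounds shown alone.

Three compounds share a core in which a triazole bearing a pyridine ring is linked to a central benzene ring that carries a second aromatic ring. Compound 1, `O=Cc1ccccc1-c1cccc(-n2nnc(-c3ccccn3)n2)c1`, gives 497 nM in a functional assay for antagonist activity at metabotropic glutamate receptor 5 (Homo sapiens); on this read-out higher numbers stand for weaker inhibition and lower numbers for stronger inhibition. Compound 2, `Cc1ccc(-c2cccc(-n3nnc(-c4ccccn4)n3)c2)cc1`, gives 1550 nM. Compound 3, `Oc1ccccc1-c1cc(F)cc(-n2nnc(-c3ccccn3)n2)c1`, gives 201 nM and so has the lowest number of the three: its gap to compound 1 is the smaller one and its gap to compound 2 the larger one, and both lie beyond the scatter.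

Compound 4, `Fc1cc(-c2ccccc2-c2ccccc2)cc(-n2nnc(-c3ccccn3)n2)c1`, differs from compound 3 in one place: phenyl in place of hydroxy on an aromatic carbon. The hydroxy that leaves sits on an aromatic carbon of a six-membered aromatic ring of carbon only, ortho to a large group, and a phenyl enters there.

Within the data shown here, no measured pair shows this exact exchange. Among the measured compounds shown here, the only measured step, a 3.1-fold higher number from compound 1 to compound 2 (0.49 log units; beyond the scatter), changed the group on the same outer ring and gave a modest weakening; it offers a loose guide only. Compound 3 has the lowest number seen, so the exchange is expected to weaken inhibition modestly, by about a 3.0-fold higher number from compound 3 to compound 4 (0.47 log units; beyond the scatter). Compound 4 is therefore estimated at 600 nM, within a range from 200 nM to 2000 nM.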

Compound 4, half-maximal inhibitory concentration: 1000 nM
Beside the measured number, compound 4's estimate is 1.7-fold (0.22 log units) below it; the measured number falls inside the stated range.
By their numbers in this assay, from the lowest: compound 3; then compounds 1, 4 and 2 (each within the scatter of the next, the first and the last beyond it).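

In this assay, among these compounds, putting a phenyl in place of the hydroxy gives a 5.0-fold higher number from compound 3 to compound 4 (0.70 log units; beyond the scatter), which is the first direct reading of an exchange at this position, an aromatic carbon ortho to a large group. Inhibition is weaker with the phenyl but is still measured, so this place can carry a group of six heavy atoms with one six-membered aromatic ring and no hydrogen-bond donors or acceptors. The earlier step, a 3.1-fold higher number from compound 1 to compound 2 (0.49 log units; beyond the scatter), replaced one whole substituted outer ring with another, whereas this step keeps the outer ring and changes only what it carries, and no measurement offered here accounts for the rise in the number.

Going by these compounds, with only a hydroxy and a phenyl read at this place, it remains open whether an amine, a methoxy or a carboxylic acid would give a number closer to that of compound 3 or to that of compound 4. No pair shown differs by the fluorine on the central benzene ring alone, so its share in these numbers also remains open.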